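Trifluoromethyl removal on the urea aryl of compound 1

The source may hold more compounds than are shown below. What is called first, only, known or untested is meant among the compounds shown, and "the series" means these compounds.

Compound 1, `COc1cc(-c2nn(-c3cccc(NC(=O)Nc4cc(C(F)(F)F)cc(C(F)(F)F)c4)c3)cc2-c2ccncc2)ccc1Cl`, is the lower of the two numbers obtained so far: in a functional assay on M14 cells (Homo sapiens) for inhibition, read by sulforhodamine B assay, with a stated time of 48 h (a lower number here means a stronger inhibitor of growth, a higher number a weaker inhibitor of growth), compound 1 gives 2550 nM. The other measured member, compound 2, `O=C(Nc1cccc(-n2cc(-c3ccncc3)c(-c3ccc(Cl)c(O)c3)n2)c1)Nc1ccc(Cl)c(Cl)c1`, carries a dichlorophenyl urea and a hydroxy group in place of the methoxy group; in this assay compound 2 gives 6970 nM, a gap from compound 1 that lies beyond the scatter. Among the compounds with values here, no pair of measured compounds differs in a single place, so the weight of any one group is still unknown.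

Compound 3, `COc1cc(-c2nn(-c3cccc(NC(=O)Nc4cccc(C(F)(F)F)c4)c3)cc2-c2ccncc2)ccc1Cl`, keeps the shared core and the urea of compound 1 and differs from it in one place: hydrogen in place of trifluoromethyl on an aromatic carbon. The trifluoromethyl that remains sits on the same ring. Within the data shown here, with only two measured values and no single-change step to lean on, the expectation is a small shift toward a higher number, possibly none beyond the scatter. The step from compound 1 to compound 3 is estimated as a 1.6-fold higher number from compound 1 to compound 3 (0.20 log units; within the scatter). In this assay compound 3 is expected at 4000 nM, within 1500 nM to 10000 nM.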

Compound 3, concentration for total growth inhibition: 1870 nM
The estimate for compound 3 lay 2.1-fold (0.33 log units) above the measured number; low and high end bracket the measured number.
By their numbers in this assay, from the lowest: compounds 3 and 1 (each within the scatter of the next); then compound 2.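

Within the data shown here, the step of a 1.4-fold lower number from compound 1 to compound 3 (0.13 log units; within the scatter) is the first single-change comparison, and in this assay it shows that hydrogen in place of trifluoromethyl on this aromatic carbon, meta to a trifluoromethyl group, gives no change that can be read beyond the scatter. Four heavy atoms leave this position without a measurable cost, so the second trifluoromethyl group of compound 1 is not needed here to hold the level of growth inhibition seen in this pair. No measurement in hand bears on why the read-out stays level, and no explanation can be offered for this step.

Whether the remaining trifluoromethyl group carries any weight stays open: compound 3 still holds it, and no single-change step among the compounds shown touches it. Also open, from the compounds shown here alone, is how a larger or differently charged group, such as an amine, a nitrile or a carboxylic acid, would read on this same aromatic carbon, given that only trifluoromethyl and hydrogen have been compared there so far.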